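Swapping the Amide Substituent in a Muscarinic Modulator Series

The compounds below may be only part of what the source reports. "The series", "measured", "known", "first", "only" and "open" are said of these compounds alone.

Measured so far in a functional assay on CHO cells for positive allosteric modulation of muscarinic acetylcholine receptor M5 (Homo sapiens), read by calcium flux; a lower number here means a smaller maximal response, a higher number a larger maximal response:
compound 1 `CCN(C(=O)C1CCN(S(=O)(=O)c2ccc3c(c2)CCO3)CC1)[C@H](C)c1ccccc1` gives 88%
compound 2 `CCN(C(=O)C1CCN(S(=O)(=O)c2ccc3cn[nH]c3c2)CC1)[C@H](C)c1ccccc1` gives 87%
compound 3 `CCN(C(=O)C1CCN(S(=O)(=O)c2ccc3[nH]ncc3c2)CC1)[C@H](C)c1ccccc1` gives 86%

All three compounds share a core and differ only in the group on the sulfonyl sulfur. Compound 2 holds the second highest of the three numbers, yet its neighbours lie within the scatter on both sides: a number 1 percentage points lower from compound 1 to compound 2 (within the scatter) and a number 1 percentage points lower from compound 2 to compound 3 (within the scatter), with a number 2 percentage points lower from compound 1 to compound 3 (within the scatter) completing the set. Exchanging the three bicyclic groups on the sulfonyl sulfur therefore left the maximal response essentially unchanged.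

Compound 4 `CCN(Cc1cccc(Cl)c1)C(=O)C1CCN(S(=O)(=O)c2ccc3cn[nH]c3c2)CC1` takes a different route. It keeps the sulfonyl group of compound 2 and instead changes the amide-type nitrogen: 3-chlorobenzyl in place of 1-phenylethyl on an amide-type nitrogen. Within the data shown here, none of the measured steps touches this position, so the three steps above give no direct guidance, and the effect of this change is untested. With the sulfonyl variations all quiet, the shared core is expected to carry similar behaviour here, giving a number 3 percentage points lower from compound 2 to compound 4 (within the scatter). Compound 4 is estimated at 84%, in the range 62% to 100%.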

Compound 4, largest response reached (reported as percent of maximum), in percent of the reference or control that the assay uses: 77%
Beside the measured number, compound 4's estimate is 7 percentage points above it, and the stated range covers the measured number.
By their numbers in this assay, from the lowest: compounds 4, 3, 2 and 1 (each within the scatter of the next, the first and the last beyond it).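

On the amide-type nitrogen, the first change at this position among the compounds shown, 3-chlorobenzyl in place of 1-phenylethyl gives a number 10 percentage points lower from compound 2 to compound 4 (within the scatter) in this assay. This step is larger than any step among the groups on the sulfonyl sulfur but stays within the scatter, so the maximal response tolerates this exchange, in which the heavy-atom count stays the same while a chlorine enters and the defined stereocentre leaves. No measurement here offers an explanation for the size of this step.

The compounds shown leave open whether the chlorine or the lost stereocentre matters more, since both changed together. A plain benzyl or a 1-(3-chlorophenyl)ethyl group on this nitrogen would separate the two, and a longer chain there would test how much else the position accepts.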